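A few compounds are considered here, and "the series" means these few. Any claim that something is new, unique, unknown or untested is made for them only; others in the source may bear on it.

Compound 3, `Nc1scc(CN2CCN(c3c(F)cccc3F)CC2)c1C(=O)c1ccc(Cl)cc1`, gives 4% in an assay on CHO cells for displacement of a labelled ligand from adenosine receptor A3 (Homo sapiens), read by scintillation counting, with a stated time of 120 min, tested at 10 uM; a lower number here means less inhibition, a higher number more inhibition at the concentration tested (going by the name of the read-out). Its two companions sit close by: compound 1, `COc1ccc(N2CCN(Cc3csc(N)c3C(=O)c3ccc(Cl)cc3)CC2)cc1`, gives 0%, and compound 2, `Nc1scc(CN2CCN(c3ccc(F)cc3F)CC2)c1C(=O)c1ccc(Cl)cc1`, gives 0%, so compound 3 cannot be set apart from either on these numbers, as the steps of a number 4 percentage points higher from compound 1 to compound 3 (within the scatter) and a number 4 percentage points higher from compound 2 to compound 3 (within the scatter) both show. The third step, no change at the digits printed from compound 1 to compound 2 (within the scatter), is likewise within the scatter.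

Compound 4, `Nc1scc(CN2CCN(c3ccc(F)c(Cl)c3)CC2)c1C(=O)c1ccc(Cl)cc1`, differs from compound 3 in one place: 3-chloro-4-fluorophenyl in place of 2,6-difluorophenyl on an amine nitrogen in a ring. All three measured steps concern a change of the aryl group on that same ring nitrogen, and none of them moved the read-out beyond the scatter, whether a methoxyphenyl gave way to a difluorophenyl or one difluorophenyl pattern to another. Compound 4 is therefore expected to behave like the others, with a step of a number 1 percentage points lower from compound 3 to compound 4 (within the scatter) in this assay. Compound 4 is estimated at 3%, within a range from 0% to 13%.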

Compound 4, a percentage reported as inhibition, at one concentration (the size of the read-out at that concentration, not a potency): 0%
The estimate for compound 4 lay 3 percentage points above the measured number; measured number inside the range.
By their numbers in this assay, from the lowest: compounds 1, 2, 4 and 3 (each within the scatter of the next).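

For the compounds shown here, compound 4 brings a chlorine onto the aryl group on the ring nitrogen, where the earlier compounds carried only methoxy or fluorine, and in this assay this gives a number 4 percentage points lower from compound 3 to compound 4 (within the scatter), no change at the digits printed from compound 2 to compound 4 (within the scatter) and no change at the digits printed from compound 1 to compound 4 (within the scatter). The position therefore shows no read-out change on going to 3-chloro-4-fluorophenyl, and the four aryl groups on that nitrogen cannot be told apart in this assay, so no order among them can be drawn. Nothing available explains this flat result.

The compounds shown leave open whether anything other than a substituted phenyl on that ring nitrogen, such as a benzyl group, a carboxylic acid or a longer alkyl chain, would lift the read-out beyond the scatter. They also leave open whether a change elsewhere on the shared core would do so.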